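The source may hold more compounds than are shown below. What is called first, only, known or untested is meant among the compounds shown, and "the series" means these compounds.

Measured compounds:
compound 1, `O=C(O)CCc1ccc(NCc2ccc(-c3ccccc3)cc2)cc1`, 251 nM
compound 2, `O=C(O)CCc1ccc(NCc2ccccc2Cl)cc1`, 3980 nM
compound 3, `O=C(O)CCc1ccc(NCc2cccc(F)c2)cc1`, 5010 nM

In a functional assay for agonist activity at Free fatty acid receptor 1 (Homo sapiens) (a lower number here means that less compound is needed, a higher number that more compound is needed for the effect), compound 3 gives the highest number of the three. Compound 2 sits close to it, within the scatter of repeated measurements, so the two cannot be ranked against each other. Compound 1 stands clearly apart, its number lying well beyond the scatter below that of compound 3, so among these three compound 1 needs the least compound for the effect.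

Compound 4, `CS(=O)(=O)Nc1cccc(CNc2ccc(CCC(=O)O)cc2)c1`, has not yet been measured in this assay. It differs from compound 3 in one place: methanesulfonamido in place of fluoro on an aromatic carbon, on an aromatic carbon of a six-membered aromatic ring of carbon only, meta to a large group. Among the compounds with values here, no pair of measured compounds shows this change, so its effect is not known from the data. For compound 4 the expected step is a 2.0-fold lower number from compound 3 to compound 4 (0.30 log units; within the scatter), a modest step downward, with the range kept open extending to no step beyond the scatter. Compound 4 is estimated at 2500 nM, between 600 nM and 10000 nM.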

Compound 4, half-maximal effective concentration: < 31700 nM
Compound 4 gave a limit, no number; the forecaster's own chance of this, stated with the estimate: 10%; the middle value does not contradict the limit.
By their numbers in this assay, from the lowest: compound 1; then compounds 2 and 3 (each within the scatter of the next).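

Within the data shown here, compound 4 gave a limit and not a number, so no step from compound 3 to compound 4 can be read: the limit of < 31700 nM in this assay, at which 1 of the 4 values shown sits. The compounds shown leave open how methanesulfonamido in place of fluoro on an aromatic carbon alters the number in this assay.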